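The source may hold more compounds than are shown below. What is called first, only, known or untested is meant among the compounds shown, and "the series" means these compounds.

Measured compounds in a functional assay (Pituitary gland cell) with Rattus norvegicus as the target; a higher number here means that more compound is needed for the effect, a lower number that less compound is needed:
- compound 1 `CNC(=O)NCc1ccccc1-c1ccc(CN2C(=O)[C@H](NC(=O)C(C)(C)N)CCc3ccccc32)cc1`: 1 nM
- compound 2 `CC(C)(N)C(=O)N[C@@H]1CCc2ccccc2N(Cc2ccc(-c3ccccc3CNC(=O)NCCO)cc2)C1=O`: 2 nM

In this assay compound 1 gives 1 nM and compound 2 gives 2 nM. For the measured compounds named here, the only step in the set, a 2.0-fold higher number from compound 1 to compound 2 (0.30 log units; within the scatter), is within the scatter, so the two numbers cannot be told apart; compound 2 simply holds one end of a pair that is, in effect, a single level.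

Compound 3 `CC(C)NC(=O)NCc1ccccc1-c1ccc(CN2C(=O)[C@H](NC(=O)C(C)(C)N)CCc3ccccc32)cc1` is the next point. It differs from compound 2 in one place: isopropyl in place of 2-hydroxyethyl on an amide-type nitrogen. Going by the values given here, the one measured step concerns the same amide-type nitrogen, but it adds a hydroxymethyl where compound 3 instead trades the 2-hydroxyethyl for a branched three-carbon group with neither donor nor acceptor. That step, a 2.0-fold higher number from compound 1 to compound 2 (0.30 log units; within the scatter), stayed within the scatter, which suggests this part of the molecule tolerates small changes without a large shift in the number. Among the compounds with values here, no other step bears on the change.

Compound 3 is therefore expected to stay near the existing pair, with a step of a 1.3-fold lower number from compound 2 to compound 3 (0.12 log units; within the scatter) that lies within the scatter. The estimate for compound 3 in this assay is 1.5 nM, with a range from 0.5 nM to 5 nM.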

Compound 3, concentration for half-maximal effect: 270 nM
For compound 3 the middle estimate is 180-fold (2.26 log units) below the measured one; measured number outside the range, above it.
By their numbers in this assay, from the lowest: compounds 1 and 2 (each within the scatter of the next); then compound 3.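

In this assay the amide-type nitrogen turns out not to be a freely tolerant position, since the exchange of 2-hydroxyethyl for isopropyl gives a 140-fold higher number from compound 2 to compound 3 (2.13 log units; beyond the scatter), although both groups have 3 heavy atoms. Isopropyl in place of methyl gives a 270-fold higher number from compound 1 to compound 3 (2.43 log units; beyond the scatter), so the change is large against both earlier compounds, while methyl and 2-hydroxyethyl remain within the scatter of each other. The loss of the hydroxyl cannot be the whole account on these compounds, as compound 1 carries methyl with no hydroxyl and still stays level with compound 2, and no measurement here gives a reason for the jump at compound 3.

The compounds shown leave open whether the step follows the branching of isopropyl or the three-carbon chain itself, a question that a straight propyl chain, an ethyl group or a cyclopropyl group on the same nitrogen would address. On these data alone, it also remains open whether a 2-methoxyethyl group would stay level with compound 2 .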